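This account rests on a few compounds, and the source may have more. Where it says the series, first, only, none or still open, it means among the compounds named here.

Compound 2 `CCOC(=O)/C=C/c1ccc(OC/C=C(\C)CCC=C(C)C)c(O)c1` and compound 1 `CCOC(=O)/C=C/c1ccc(OC/C=C(\C)CCC=C(C)C)c(OC)c1` share one core and differ in a single place. In an assay on isolated protein for inhibition of geranylgeranyl pyrophosphate synthase (Homo sapiens), tested at 100 uM (a lower number here means less inhibition, a higher number more inhibition at the concentration tested (going by the name of the read-out)), compound 2 gives -7.4%, while compound 1 gives 5.5%; the change methyl in place of hydrogen on an oxygen on an aromatic ring made a step of a number 12.9 percentage points higher from compound 2 to compound 1 (beyond the scatter). Compound 3 `CC(C)=CCC/C(C)=C/CC/C(C)=C/COc1ccc(/C=C/C(=O)O)cc1O` is built on a different core, and the difference between the two cores is not broken down here. In this assay compound 3 gives 16.2%, the highest of the three numbers. Compound 4 `COc1cc(/C=C/C(=O)O)ccc1OC/C=C(\C)CC/C=C(\C)CCC=C(C)C` has not yet been measured; it differs from compound 3 by methyl in place of hydrogen on an oxygen on an aromatic ring, the same change as that from compound 2 to compound 1. In this assay this change is expected to give a step of a number 10.8 percentage points higher from compound 3 to compound 4 (beyond the scatter), because the matching step earlier gave a number 12.9 percentage points higher from compound 2 to compound 1 (beyond the scatter). Compound 4 is therefore estimated at 27%, expected to lie between 13% and 41%.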

Compound 4, a percentage reported as inhibition, at one concentration (the size of the read-out at that concentration, not a potency): 11%
Compound 4: middle estimate off by 16 percentage points, on the high side; measured number below the stated range.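

On the core of compound 3, hydroxy to methoxy made a step of a number 5.2 percentage points lower from compound 3 to compound 4 (within the scatter). Set beside the earlier step, the change did not carry over from one core to the other in this assay: the same change on two cores in this assay, a number 12.9 percentage points higher (beyond the scatter) from compound 2 to compound 1 and a number 5.2 percentage points lower (within the scatter) from compound 3 to compound 4, 18.1 percentage points apart, beyond the scatter of two such steps

This rests on one pair per core, so it shows that the earlier step could not be relied on here, but not why the two cores differ or how the change would behave on a third core. Going by these compounds, how an ethoxy group or an amine in that place would read remains open. Also open, on these data alone, is which part of the difference between the two cores separates the two steps.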